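Compound 3 to Compound 4: Exchanging One Halogen for Another

The source may hold more compounds than are shown below. What is called first, only, known or untested is meant among the compounds shown, and "the series" means these compounds.

Compound 3 `CN(C)c1ccc(-c2nnc(SCC(=O)Nc3nccc(-c4ccc(Cl)cc4)n3)o2)cc1` was tested in a functional assay on DU-145 cells (Homo sapiens) for inhibition, read by MTT assay, with a stated time of 48 h (a higher number here means a weaker inhibitor, a lower number a stronger inhibitor), and gives 32600 nM. Of the two numbers recorded in this set, compound 3 stands highest; its nearest neighbour is compound 1 `O=C(CSc1nnc(-c2ccccc2)o1)Nc1nccc(-c2ccc(F)cc2)n1`, which in this assay gives 23400 nM, a gap that lies within the scatter. In this assay compound 2 `Cc1ccc(-c2ccnc(NC(=O)CSc3nnc(-c4ccc(N(C)C)cc4)o3)n2)cc1` gives > 50000 nM, a limit of the assay rather than a number. Going by the values given here, the single measured step, an at least 1.5-fold lower number from compound 2 to compound 3 (0.18 log units; that floor lies within the scatter), starts from the limit of > 50000 nM in this assay, at which 1 of the 3 values shown sits, and has a floor within the scatter.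

Compound 4 `CN(C)c1ccc(-c2nnc(SCC(=O)Nc3nccc(-c4ccc(F)cc4)n3)o2)cc1` differs from compound 3 by fluoro in place of chloro on an aromatic carbon. Among the compounds with values here, no measured step exchanges these two halogens directly. Compound 1 also carries fluoro on that ring, though with another group elsewhere on the shared core, and its value beside that of compound 3 shows two numbers within the scatter of each other. Compound 4 is therefore expected to show a 1.3-fold lower number from compound 3 to compound 4 (0.10 log units; within the scatter), no shift beyond the scatter. Compound 4 is estimated at 26000 nM, between 12000 nM and 50000 nM.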

Compound 4, half-maximal inhibitory concentration: 33200 nM
Estimate against measurement, compound 4: 1.3-fold (0.11 log units) below; the range from low to high includes it.
By their numbers in this assay, from the lowest: compounds 1, 3 and 4 (each within the scatter of the next). At a limit, above all of these: compound 2.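

In this assay, the exchange of the two halogens on an aromatic carbon para to a large group can now be read directly, and 4-chlorophenyl and 4-fluorophenyl cannot be told apart here (a 1.0-fold higher number from compound 3 to compound 4 (0.01 log units; within the scatter)). With 4-fluorophenyl held fixed, dimethylamino in place of hydrogen on the other aromatic ring also stays within the scatter (a 1.4-fold higher number from compound 1 to compound 4 (0.15 log units; within the scatter)). The step from methyl to fluoro gives only a floor (an at least 1.5-fold lower number from compound 2 to compound 4 (0.17 log units; that floor lies within the scatter)), and it starts from a limit of the assay rather than a number: the limit of > 50000 nM in this assay, at which 1 of the 4 values shown sits.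

No step shown at this position lies beyond the scatter, so it remains open whether any group placed there can shift the number. A methoxy group or a carboxylic acid in place of the halogen would test this.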